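Taking one fluoro group off compound 3

This account rests on a few compounds, and the source may have more. Where it says the series, first, only, none or still open, it means among the compounds named here.

Measured in an ADME assay on microsomes from liver (Homo sapiens) for metabolic stability, read by LC-MS, using NADPH; on this read-out higher numbers stand for a longer-lived compound and lower numbers for a shorter-lived compound:
- compound 1 `CCC(C)(C)C(=O)N(O)Cc1cc(F)cc(F)c1F` gives 1.11 h
- compound 2 `CCC(C)(C)C(=O)N(O)Cc1ccc(F)cc1F` gives 3.3 h
- compound 3 `CCC(C)(C)C(=O)N(O)Cc1cc(F)c(F)c(F)c1` gives 1.1 h

In this assay, compound 3 and compound 1 lie within the scatter of each other. Compound 2 has the higher number, and its gap to compound 3 lies beyond the scatter.

Compound 4 `CCC(C)(C)C(=O)N(O)Cc1ccc(F)c(F)c1` is the next compound to read. It differs from compound 3 by hydrogen in place of fluoro on an aromatic carbon, at a place ortho to a fluoro group, meta to a fluoro group and meta to a large group.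

For the measured compounds named here, no two measured compounds differ in one place only, so this step has no direct precedent. Going by the values given here, the only guide is compound 2 at 3.3 h, which carries fewer fluoro groups than compound 1 and compound 3. Compound 4 shares that lower count, but its fluoro groups sit elsewhere on the ring, so the guide is weak. A small upward move is expected, probably not beyond the scatter. The expected step is a 1.6-fold higher number from compound 3 to compound 4 (0.21 log units; within the scatter).

Compound 4 is estimated at 1.8 h, with an expected range from 0.9 h to 3.6 h.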

Compound 4, half-life: 1.78 h
Estimate against measurement, compound 4: 1.0-fold (0.00 log units) above; measured number inside the range.
By their numbers in this assay, from the lowest: compounds 3, 1, 4 and 2 (each within the scatter of the next, the first and the last beyond it).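

Working notes on the series: in this assay, hydrogen in place of fluoro on an aromatic carbon, at the place ortho to a fluoro group, meta to a fluoro group and meta to a large group, gives a 1.6-fold higher number from compound 3 to compound 4 (0.21 log units; within the scatter). For the compounds shown here, this is the first one-place step, and it shows that this fluoro group can be exchanged for hydrogen, in this one context, without a shift beyond the scatter on this read-out. No data that could account for the size of this step are at hand.

As far as these compounds go, the reading rests on a single exchange at a single place on the shared core, so it remains open whether chloro, methyl, methoxy or a nitrile at this same place would stay within the scatter of compound 3 or move clear of it. Also open, from the compounds shown here alone, are the same exchange of fluoro for hydrogen at the other fluorinated places on the aromatic ring, and whether this step would hold if a longer chain or a cyclopropyl group stood on the carbonyl side of the core.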